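Chain-length step on the shared core under the cytotoxicity read-out

The source may hold more compounds than are shown below. What is called first, only, known or untested is meant among the compounds shown, and "the series" means these compounds.

Measured so far:
compound 1, `CCCCNc1nc(NCc2ccco2)c2ccccc2n1`: 94.8%
compound 2, `CCCCCNc1nc(NCc2ccco2)c2cc(F)ccc2n1`: 94.2%

In a functional assay on HCT-116 cells (Homo sapiens) for cytotoxicity, read by MTT assay, with a stated time of 2 days, tested at 10 uM (on this read-out lower numbers stand for less inhibition and higher numbers for more inhibition at the one concentration tested (going by the name of the read-out)), compound 1 gives 94.8% and compound 2 gives 94.2%. The two numbers sit within the scatter of each other, so on the data at hand compound 2 stands level with compound 1, and neither can be placed ahead of the other. Both numbers lie high at the single concentration tested.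

Compound 3, `CCCCNc1nc(NCc2ccco2)c2cc(F)ccc2n1`, is the next point in the series. It differs from compound 2 by hydrogen in place of methyl on a saturated chain carbon, four bonds along the chain from a nitrogen on an aromatic ring. Going by the values given here, no pair of measured compounds covers this change, so no measured step can be read across; the expectation rests only on the level of compound 2.

Among the compounds with values here, the step from compound 2 to compound 3 is expected to be a number 1.2 percentage points lower from compound 2 to compound 3 (within the scatter), that is, nothing beyond the scatter, because compound 2 gives 94.2% in this assay and nothing among the measured compounds shows that hydrogen in place of methyl at this position moves the number. Compound 3 is therefore estimated at 93%, with a range from 84% to 98%.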

Compound 3, a percentage reported as inhibition, at one concentration (the size of the read-out at that concentration, not a potency): 87.8%
Estimate against measurement, compound 3: 5.2 percentage points above; measured number inside the range.
By their numbers in this assay, from the lowest: compounds 3, 2 and 1 (each within the scatter of the next).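

In this assay, hydrogen in place of methyl on a saturated chain carbon, four bonds along the chain from a nitrogen on an aromatic ring, gives a number 6.4 percentage points lower from compound 2 to compound 3 (within the scatter) as the first reading of this position, so this one-carbon change to the chain is not shown to move the number beyond the scatter. Compound 3 also makes the aromatic position readable: fluoro in place of hydrogen on an aromatic carbon gives a number 7 percentage points lower from compound 1 to compound 3 (within the scatter) on the shared core, and this change likewise stays inside the scatter. No measured information bears on either step, so neither can be given a cause.

The compounds shown leave open whether a longer chain such as octyl, or a chain ending in an amine or a carboxylic acid, would give a step beyond the scatter at this position. Going by these compounds alone, they also leave open whether chloro or methoxy in place of fluoro on the same aromatic carbon would do so, and a single-concentration read-out gives no potency for any compound.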